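Acetylating the sulfonamide of a dihydroxyphenyl pyrazole

A few compounds are considered here, and "the series" means these few. Any claim that something is new, unique, unknown or untested is made for them only; others in the source may bear on it.

Compound 3, `NS(=O)(=O)c1ccc(-n2nc(-c3ccccc3)cc2-c2cc(O)ccc2O)cc1`, gives 88100 nM in a functional assay on cells (Cancer cell lines, Homo sapiens) for cytotoxicity, read by sulforhodamine B assay, with a stated time of 48 h (on this read-out higher numbers stand for weaker inhibition of growth and lower numbers for stronger inhibition of growth), and stands highest of the three measured numbers. For the measured compounds named here, compound 2, `Oc1ccc(O)c(-c2cc(-c3ccccc3)nn2-c2ccccc2)c1`, gives 22600 nM, and the change that separates them, a 3.9-fold higher number from compound 2 to compound 3 (0.59 log units; beyond the scatter), is the only single-site step measured. Compound 1, `COc1ccc(OC)c(-c2cc(-c3ccccc3)nn2-c2ccc(S(=O)(=O)NC(C)=O)cc2)c1`, gives 13300 nM and carries the acetylsulfamoyl group already, though it differs from compound 3 in two places, so its value only hints that the acetylated sulfonamide is compatible with growth inhibition. Compound 4, `CC(=O)NS(=O)(=O)c1ccc(-n2nc(-c3ccccc3)cc2-c2cc(O)ccc2O)cc1`, differs from compound 3 by acetyl in place of hydrogen on a sulfonamide nitrogen. Going by the values given here, no measured step isolates this change; the expected step of a 1.8-fold lower number from compound 3 to compound 4 (0.25 log units; within the scatter) is therefore small, leaning toward a lower number. Compound 4 is estimated at 50000 nM, within 15000 nM to 160000 nM.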

Compound 4, concentration for 50% growth inhibition: 78100 nM
Compound 4: the middle estimate sits 1.6-fold (0.19 log units) below what was measured, within the range that was stated.
By their numbers in this assay, from the lowest: compounds 1 and 2 (each within the scatter of the next); then compounds 4 and 3 (each within the scatter of the next).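

In this assay, acetyl in place of hydrogen on the sulfonamide nitrogen changes almost nothing, a 1.1-fold lower number from compound 3 to compound 4 (0.05 log units; within the scatter), so it does not undo the effect of the sulfamoyl group. The acetylsulfamoyl group still leaves a 3.5-fold higher number from compound 2 to compound 4 (0.54 log units; beyond the scatter), and the growth inhibition seen with the 2,5-dimethoxyphenyl group does not carry over to the 2,5-dihydroxyphenyl group, a 5.9-fold higher number from compound 1 to compound 4 (0.77 log units; beyond the scatter). Nothing available here explains these steps. Going by these compounds, whether a longer acyl chain such as butyryl, a benzoyl group or a methyl group on that nitrogen would behave like acetyl remains open.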